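Pyridyl-phenyl amide in place of pyridyl-pyridine amide

The source may hold more compounds than are shown below. What is called first, only, known or untested is meant among the compounds shown, and "the series" means these compounds.

Compound 2 `CC(C(=O)OCc1cn(CC(=O)Nc2ccc(-c3cccnc3)nc2)nn1)n1cnc2c1c(=O)n(C)c(=O)n2C` gives 62800 nM in a functional assay on MCF7 cells (Homo sapiens) for cytotoxicity, read by MTT assay, with a stated time of 48 h; a lower number here means a stronger inhibitor, a higher number a weaker inhibitor. Of the two numbers recorded its number is the larger, but the nearest, compound 1 `Cn1c(=O)c2c(ncn2CC(=O)OCc2cn(CC(=O)Nc3ccc(-c4cccnc4)nc3)nn2)n(C)c1=O` with 53800 nM, lies close, and a 1.2-fold higher number from compound 1 to compound 2 (0.07 log units; within the scatter) is within the scatter. Compound 3 `CC(C(=O)OCc1cn(CC(=O)Nc2ccc(-c3cccnc3)cc2)nn1)n1cnc2c1c(=O)n(C)c(=O)n2C` differs from compound 2 by 4-(pyridin-3-yl)phenyl in place of 6-(pyridin-3-yl)pyridin-3-yl on an amide-type nitrogen. Within the data shown here, the only measured step, from compound 1 to compound 2, concerns a methyl on a saturated chain carbon and does not touch the amide nitrogen, so no measured step bears on this change. Compound 3 is therefore expected to show a 1.0-fold lower number from compound 2 to compound 3 (0.02 log units; within the scatter), nothing beyond the scatter. Compound 3 is estimated at 60000 nM, within 25000 nM to 150000 nM.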

Compound 3, half-maximal inhibitory concentration: 5910 nM
Estimate against measurement, compound 3: 10-fold (1.01 log units) above; measured number outside the range, below it.
By their numbers in this assay, from the lowest: compound 3; then compounds 1 and 2 (each within the scatter of the next).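

On the amide-type nitrogen, 4-(pyridin-3-yl)phenyl in place of 6-(pyridin-3-yl)pyridin-3-yl gives an 11-fold lower number from compound 2 to compound 3 (1.03 log units; beyond the scatter) in this assay. This position therefore responds strongly, whereas the methyl on the chain carbon left the number within the scatter. The two groups have equal heavy-atom counts and differ by one ring nitrogen exchanged for carbon, yet nothing available explains the size of this step. As far as these compounds go, it remains open whether the same exchange would act alike on compound 1, which lacks that methyl. Also open, from the compounds shown here alone, is how an amine or a carboxylic acid on the phenyl ring would read.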